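Chloro on the benzyl ring of the shared core

The source may report more compounds than this note shows. Statements on the series, on what has been measured and on what is new or still open speak of the compounds shown alone.

Among the measured compounds shown here, compound 1 `Nc1nc(NCc2ccccc2)nc(-c2ccccc2CO)n1` gives 4.35 in a functional assay on cells for positive allosteric modulation of G-protein coupled receptor 68 (Homo sapiens), read by a luciferase reporter and cAMP accumulation, with a stated time of 30 min, at pH 6.8 and pH 8.3, in the presence of a further agent that is not named here (on this read-out lower numbers stand for lower potency and higher numbers for higher potency (the scale is a negative logarithm)), the second highest of the three numbers so far. Compound 2 `CCNc1nc(NCc2ccccc2)nc(-c2ccccc2CO)n1` gives 4.63; the step of a number 0.28 log units higher from compound 1 to compound 2 (within the scatter) stays within scatter. Compound 3 `Nc1nc(NCc2ccccc2)nc(-c2c(F)cccc2CO)n1` gives 3.69, and a number 0.66 log units lower from compound 1 to compound 3 (beyond the scatter) lies beyond it. Compound 4 `Nc1nc(NCc2ccccc2Cl)nc(-c2ccccc2CO)n1` carries chloro in place of hydrogen on an aromatic carbon. For the measured compounds named here, no measured step touches the benzyl ring; the only halogen step, a number 0.66 log units lower from compound 1 to compound 3 (beyond the scatter), sits on a different ring and lowered the number modestly, while the ethyl step was flat. Lacking a direct precedent, a step of a number 0.05 log units lower from compound 1 to compound 4 (within the scatter) is expected, small and not clearly beyond scatter, with a lean toward lower. Compound 4 is therefore estimated at 4.3, range 3.7 to 4.9.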

Compound 4, negative logarithm of the antagonist equilibrium constant: 5.07
Beside the measured number, compound 4's estimate is 0.77 log units below it, outside the stated range (above it).
By their numbers in this assay, from the lowest: compound 3; then compounds 1 and 2 (each within the scatter of the next); then compound 4.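

Among the compounds shown here, on the benzyl ring, the change from benzyl to 2-chlorobenzyl gives a number 0.72 log units higher from compound 1 to compound 4 (beyond the scatter) in this assay as the first measured step at this position and the first upward step beyond the scatter. The only other halogen step, a number 0.66 log units lower from compound 1 to compound 3 (beyond the scatter) on a different ring with fluoro, runs the opposite way, so a halogen has no single direction across the compounds shown. No available evidence explains the rise.

On these data alone, whether bromo, methyl or methoxy at this place would give a similar step remains open. So does whether the chloro step would hold with ethyl on the amino nitrogen.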